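Methoxy on the fused ring: compound 1 to compound 4

A few compounds are considered here, and "the series" means these few. Any claim that something is new, unique, unknown or untested is made for them only; others in the source may bear on it.

Working notes on the series. In a functional assay on A549 cells (Homo sapiens) for cytotoxicity, read by MTT assay, with a stated time of 48 h (a higher number here means a weaker inhibitor, a lower number a stronger inhibitor), compound 1 `CCOC(=O)c1c(-c2cc3ccccc3oc2=O)nn(-c2cccc(C)c2)c1C(=O)OCC` gives 52000 nM. For the measured compounds named here, it has the lowest of the three numbers measured so far, but the gaps to the others fall within the scatter: compound 2 `CCOC(=O)c1c(-c2cc3ccccc3oc2=O)nn(-c2cccc(F)c2)c1C(=O)OCC` gives 59000 nM, and compound 3 `CCOC(=O)c1c(-c2cc3ccccc3oc2=O)nn(-c2ccc(Br)cc2)c1C(=O)OCC` gives 100000 nM. The three measured steps, a 1.1-fold higher number from compound 1 to compound 2 (0.05 log units; within the scatter), a 1.9-fold higher number from compound 1 to compound 3 (0.28 log units; within the scatter) and a 1.7-fold higher number from compound 2 to compound 3 (0.23 log units; within the scatter), all change the substituent on the aryl ring attached to the aromatic nitrogen, and none moves this assay beyond the scatter.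

Compound 4 `CCOC(=O)c1c(-c2cc3ccc(OC)cc3oc2=O)nn(-c2cccc(C)c2)c1C(=O)OCC` differs from compound 1 by methoxy in place of hydrogen on an aromatic carbon. Going by the values given here, this change sits on the fused ring system of the shared core, a part of the molecule that no measured step touches, so no step bears on it directly. What the measured steps do show is that the series has so far been indifferent to substituent changes in this assay. With nothing measured on the fused ring, the expectation rests on that indifference alone, and no step beyond the scatter is expected in either direction. The expected step of a 1.0-fold lower number from compound 1 to compound 4 (0.02 log units; within the scatter) therefore stays within the scatter. For compound 4 the estimate in this assay is 50000 nM, with a range from 25000 nM to 100000 nM.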

Compound 4, half-maximal inhibitory concentration: 171000 nM
Beside the measured number, compound 4's estimate is 3.4-fold (0.53 log units) below it; the whole stated range lies below it.
By their numbers in this assay, from the lowest: compounds 1, 2, 3 and 4 (each within the scatter of the next, the first and the last beyond it).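

In this assay, methoxy in place of hydrogen on an aromatic carbon of the fused system gives a 3.3-fold higher number from compound 1 to compound 4 (0.52 log units; beyond the scatter), a modest step and the first in the series to lie beyond the scatter. The position on the fused system therefore responds to substitution, whereas the steps among compounds 1, 2 and 3 on the aryl ring attached to the aromatic nitrogen all stayed within the scatter, and the response here runs towards a weaker inhibitor. Nothing available accounts for this step, so its origin remains unexplained.

Going by these compounds, whether the loss belongs to methoxy itself or would follow any group on this carbon stays open, as does the outcome with a hydroxy group, an amine or a longer chain such as ethoxy at the same place. The compounds shown also carry methoxy only with 3-methylphenyl on the aromatic nitrogen, so it is unknown whether the step holds with 3-fluorophenyl or 4-bromophenyl there.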